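The compounds below may be only part of what the source reports. "The series", "measured", "known", "first", "only" and "open" are said of these compounds alone.

Compound 1 `Cc1ccnc(/C(N)=N/NC(=S)N2CCSCC2)c1` and compound 2 `N/C(=N\NC(=S)N1CCSCC1)c1ccccn1` share the same core and differ only in that hydrogen stands in place of methyl on an aromatic carbon. In a functional assay on A-431 cells (Homo sapiens) for cytotoxicity, read by MTT assay, with a stated time of 72 h, tested at 100 uM (on this read-out higher numbers stand for more inhibition of growth at the one concentration tested and lower numbers for less inhibition of growth), compound 1 gives 79.6%, while compound 2 gives 80.8%. Among the compounds with values here, the step of a number 1.2 percentage points higher from compound 1 to compound 2 (within the scatter) lies within the scatter, so the two numbers cannot be told apart; compound 1 simply holds the lower of the two numbers, with compound 2 as its only neighbour.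

Compound 3 `Cc1ccnc(/C(N)=N/NC(=S)N2CCCC2)c1` has not yet been measured. It differs from compound 1 in pyrrolidin-1-yl in place of thiomorpholin-4-yl on a thiocarbonyl carbon. Within the data shown here, no measured pair changes the ring on the thiocarbonyl carbon, so nothing seen so far speaks to this change directly; the only measured step of a number 1.2 percentage points higher from compound 1 to compound 2 (within the scatter) concerns a different part of the molecule and stayed within the scatter.

Among the measured compounds shown here, because compound 1 gives 79.6% and no measured step points elsewhere, compound 3 is expected to show a step of a number 5.6 percentage points lower from compound 1 to compound 3 (within the scatter) of modest size, with a wide range allowed. The estimate for compound 3 in this assay is 74%, between 52% and 92%.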

Compound 3, percent growth inhibition at one concentration: 86.9%
The estimate for compound 3 lay 12.9 percentage points below the measured number; the measured number falls inside the stated range.
By their numbers in this assay, from the lowest: compounds 1, 2 and 3 (each within the scatter of the next).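

Within the data shown here, this is the first measured change on the thiocarbonyl carbon: in this assay, pyrrolidin-1-yl in place of thiomorpholin-4-yl gives a number 7.3 percentage points higher from compound 1 to compound 3 (within the scatter). The swap replaces a six-membered ring holding a sulfur with a five-membered ring holding none, yet compound 1 and compound 3 cannot be told apart at the one concentration tested, so this position accepts at least these two rings without a difference that rises above the scatter. Nothing available beyond these growth-inhibition numbers bears on how either ring acts in the cells, so the result remains a plain observation.

Ring size and the ring sulfur changed together in this one step, so their separate contributions remain open; piperidin-1-yl, a six-membered ring without the sulfur, and morpholin-4-yl, with oxygen in the sulfur's place, would help pull them apart. On these data alone, it also remains open whether this carbon needs a ring at all, a question that an open-chain group such as dimethylamino would address.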